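The compounds below may be only part of what the source reports. "The series", "measured", "known", "first", "only" and "open" are said of these compounds alone.

In a functional assay for antagonist activity at metabotropic glutamate receptor 5 (Rattus norvegicus) (a lower number here means a stronger inhibitor, a higher number a weaker inhibitor), compound 1, with structure `Cc1ccccc1-c1cc(F)cc(-n2nnc(-c3ccccn3)n2)c1`, gives 120 nM. Compound 2, with structure `Cc1cnccc1-c1cc(F)cc(-n2nnc(-c3ccccn3)n2)c1`, gives 63 nM in this assay. Going by the values given here, the single measured step, a 1.9-fold lower number from compound 1 to compound 2 (0.28 log units; within the scatter), is within the scatter, so although compound 2 carries the smaller of the two numbers, the two compounds cannot be told apart on these data.

Compound 3, with structure `Cc1ccncc1-c1cc(F)cc(-n2nnc(-c3ccccn3)n2)c1`, differs from compound 2 by one change: 4-methylpyridin-3-yl in place of 3-methylpyridin-4-yl on an aromatic carbon. Among the compounds with values here, the only step available for comparison is a 1.9-fold lower number from compound 1 to compound 2 (0.28 log units; within the scatter), which moves a methylpyridinyl group around and stays within the scatter; nothing measured here speaks for a step beyond the scatter from this further rearrangement of the same group. Compound 3 is therefore expected to give about 80 nM in this assay, within a range of 30 nM to 250 nM. This estimate for compound 3 corresponds to an expected step of a 1.3-fold higher number from compound 2 to compound 3 (0.10 log units; within the scatter).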

Compound 3, half-maximal inhibitory concentration: 5 nM
Estimate against measurement, compound 3: 16-fold (1.20 log units) above; measured number outside the range, below it.
By their numbers in this assay, from the lowest: compound 3; then compounds 2 and 1 (each within the scatter of the next).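

At this aromatic carbon, the arrangement of atoms within the group matters greatly: with the same atoms joined differently, 4-methylpyridin-3-yl in place of 3-methylpyridin-4-yl gives a 13-fold lower number from compound 2 to compound 3 (1.10 log units; beyond the scatter) in this assay. The earlier pair did not show this, as its single step stayed within the scatter, whereas 4-methylpyridin-3-yl in place of 2-methylphenyl gives a 24-fold lower number from compound 1 to compound 3 (1.38 log units; beyond the scatter), so among these three compounds, having a methylpyridinyl group at this position is not enough on its own to give the large drop. Nothing available here explains the difference between the two methylpyridinyl groups.

As far as these compounds go, how plain pyridin-3-yl, or a methoxy group or a chlorine atom in place of the methyl group, would compare remains open. Also open, from the compounds shown here alone, is whether 4-methylpyridin-3-yl would keep this low number if a nitrile replaced the fluoro group on the core.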